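Methyl to benzyl in a series held at its limit

The source may report more compounds than this note shows. Statements on the series, on what has been measured and on what is new or still open speak of the compounds shown alone.

Compound 1 `CN(O)/C=C\C(=O)c1ccc2ccccc2c1`: > 10000 nM
Compound 2 `CN(O)/C=C\C(=O)c1ccc([N+](=O)[O-])cc1`: > 10000 nM
Compound 3 `CN(O)/C=C\C(=O)c1ccc(Cl)cc1`: > 10000 nM

Each of these three entries is a limit and not a number. In a functional assay on cells (Homo sapiens) for inhibition (on this read-out lower numbers stand for stronger inhibition and higher numbers for weaker inhibition), compound 1 gives > 10000 nM, so its starting point is a limit only. The same holds across the measured set: the limit of > 10000 nM in this assay, at which 3 of the 3 values shown sit.

Compound 4 `O=C(/C=C\N(O)Cc1ccccc1)c1ccc2ccccc2c1` differs from compound 1 at one place, with phenyl in place of hydrogen on a saturated chain carbon bound to an amine nitrogen, which reads as methyl to benzyl: phenyl in place of hydrogen on a saturated chain carbon bound to an amine nitrogen.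

Within the data shown here, only one measured step exists, and it lies at a different place, on an aromatic carbon: a step that the two limits leave unreadable from compound 2 to compound 3. Among the measured compounds shown here, it gives no size to carry over, and no measured step touches the chain on the amine nitrogen. The expectation in this assay therefore rests on little: a modest move toward stronger inhibition or nothing readable, and a result that again reports only a limit is quite likely. The estimated change is an at least 1.1-fold lower number from compound 1 to compound 4 (0.04 log units; that floor lies within the scatter). For compound 4 the expected value is 9000 nM, with an estimated range of 2000 nM to 20000 nM.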

Compound 4, half-maximal inhibitory concentration: 5400 nM
Compound 4: middle estimate off by 1.7-fold (0.22 log units), on the high side, within the range that was stated.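

Methyl to benzyl on the amine nitrogen gives the only compound shown that reads as a number rather than a limit in this assay, with the step reading an at least 1.8-fold lower number from compound 1 to compound 4 (0.26 log units; that floor lies within the scatter). Compound 1 gives > 10000 nM, which is a limit, so the step is known only as a floor and the full size of the change cannot be read. The chain on the amine nitrogen is therefore the one place in the series where a change has been seen to leave the limit, while the chloro and nitro pair on the aromatic carbon stays unreadable: the limit of > 10000 nM in this assay, at which 3 of the 4 values shown sit.

As far as these compounds go, it remains open whether the phenyl group itself carries this step, since an ethyl group, a cyclohexylmethyl group or a longer phenethyl chain on the same nitrogen would be needed to separate the phenyl group from the added chain alone. From the compounds shown here alone, it is also open whether the same change would lift compound 2 and compound 3 off the limit, and whether an amine or a carboxylic acid on the new phenyl group would move the number in either direction.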